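Ester variation on the shared core

A few compounds are considered here, and "the series" means these few. Any claim that something is new, unique, unknown or untested is made for them only; others in the source may bear on it.

In an ADME assay on HepG2 2.2.15 cells (Homo sapiens) for cytotoxicity (on this read-out lower numbers stand for higher toxicity in this test and higher numbers for lower toxicity in this test), compound 1 `O=C(O)CCCC(=O)OCCc1c(-c2ccccc2Cl)c2cc(Cl)ccc2[nH]c1=O` gives 110000 nM and compound 2 `O=C(OCCc1c(-c2ccccc2Cl)c2cc(Cl)ccc2[nH]c1=O)c1ccco1` gives 98000 nM. Among the compounds with values here, the two values are separated by a 1.1-fold lower number from compound 1 to compound 2 (0.05 log units; within the scatter), so compound 2 stands level with compound 1, and the pair marks no difference so far.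

Compound 3 `O=C(CN1C(=O)c2ccccc2C1=O)OCCc1c(-c2ccccc2Cl)c2cc(Cl)ccc2[nH]c1=O` keeps the shared core and the ester. Its difference from compound 2 is a group of 12 heavy atoms (9 carbon, 1 nitrogen, 2 oxygen; one five-membered non-aromatic ring with 1 hetero atom, one six-membered aromatic ring of carbon only) in place of a group of 5 heavy atoms (4 carbon, 1 oxygen; one five-membered aromatic ring with 1 hetero atom), on a carbonyl carbon. Within the data shown here, the only measured step that bears on this change is the exchange on the same carbonyl carbon, a 1.1-fold lower number from compound 1 to compound 2 (0.05 log units; within the scatter), in which furan-2-yl takes the place of 3-carboxypropyl. That step stays within the scatter, although the two groups differ considerably. Among the measured compounds shown here, it is still a single step, and no measured compound carries a group with a five-membered non-aromatic ring at this place. No step beyond the scatter is therefore expected in this assay, and neither direction is favoured. The expected outcome is a 1.1-fold lower number from compound 2 to compound 3 (0.04 log units; within the scatter). Compound 3 is estimated at 90000 nM, with an expected range of 40000 nM to 180000 nM.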

Compound 3, half-maximal cytotoxic concentration: 960000 nM
For compound 3 the middle estimate is 11-fold (1.03 log units) below the measured one, outside the stated range (above it).
By their numbers in this assay, from the lowest: compounds 2 and 1 (each within the scatter of the next); then compound 3.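

On the carbonyl carbon of the ester, the exchange now moves the read-out in this assay: there is a 9.8-fold higher number from compound 2 to compound 3 (0.99 log units; beyond the scatter), and the same group gives an 8.7-fold higher number from compound 1 to compound 3 (0.94 log units; beyond the scatter), so this place in the series is not indifferent to the group it carries. The earlier exchange, a 1.1-fold lower number from compound 1 to compound 2 (0.05 log units; within the scatter), had stayed within the scatter, so the two groups of compounds 1 and 2 gave no sign of such a step; in this test the higher number of compound 3 stands for lower toxicity. No measured information is available on what lies behind the step.

Compound 3 differs from compound 2 at this place in several counted features together, namely the number of heavy atoms, the nitrogen, the five-membered non-aromatic ring, the six-membered aromatic ring and the two double bonds outside aromatic rings, so the compounds shown cannot assign the step to any one of them. As far as these compounds go, it remains open whether a plain phenyl, a simple methyl or a chain ending in an amine on the same carbonyl carbon would stand with compound 3 or with compounds 1 and 2.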